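A Biaryl Replaces the Thioether on a Known Antagonist Scaffold

A few compounds are considered here, and "the series" means these few. Any claim that something is new, unique, unknown or untested is made for them only; others in the source may bear on it.

Two compounds share one amide-linked core and differ only in the group attached to the benzylic ring. For the measured compounds named here, compound 2 `CC(C(=O)NCc1ccc(C(F)(F)F)cc1SC1CCCCC1)c1ccc(NS(C)(=O)=O)c(F)c1` carries a cyclohexylsulfanyl group and, in an assay on CHO cells for antagonist activity at transient receptor potential cation channel subfamily V member 1 (Homo sapiens), read by FLIPR (on this read-out higher numbers stand for weaker inhibition and lower numbers for stronger inhibition), compound 2 gives 0.5 nM, the only number recorded for this series. Compound 1 `CC(C(=O)NCc1ccc(C(F)(F)F)cc1SCCCO)c1ccc(NS(C)(=O)=O)c(F)c1` carries a 3-hydroxypropylsulfanyl chain instead, and in this assay compound 1 is recorded as "not active" (no number reported), with no number attached.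

Compound 3 `COc1ccc(-c2cc(C(F)(F)F)ccc2CNC(=O)C(C)c2ccc(NS(C)(=O)=O)c(F)c2)cc1OC` has not been measured. Its difference from compound 2 is 3,4-dimethoxyphenyl in place of cyclohexylsulfanyl on an aromatic carbon. The new group sits on an aromatic carbon, ortho to a large group and meta to a trifluoromethyl group, exactly where the cyclohexylsulfanyl group stood.

Going by the values given here, no measured pair here shows what such a swap does. Among the compounds with values here, the only hint is that compound 2, whose value is 0.5 nM, holds a six-membered non-aromatic ring of carbon only, whereas compound 1, recorded as "not active" (no number reported), holds a short chain with a hydrogen-bond donor. A loss is expected, of about a 40-fold higher number from compound 2 to compound 3 (1.60 log units; beyond the scatter), well beyond the scatter. Compound 3 is therefore estimated at 20 nM, with a range from 2 nM to 200 nM.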

Compound 3, inhibition constant: 8.6 nM
For compound 3 the middle estimate is 2.3-fold (0.37 log units) above the measured one, within the range that was stated.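

Putting 3,4-dimethoxyphenyl in place of cyclohexylsulfanyl gives a 17-fold higher number from compound 2 to compound 3 (1.24 log units; beyond the scatter) in this assay, so this swap costs a large share of the inhibition seen with compound 2. The position is still not closed to an aromatic ring: with a six-membered aromatic ring of carbon only and no sulfur at this aromatic carbon, compound 3 gives 8.6 nM and remains in the nanomolar range, while compound 1, with its 3-hydroxypropylsulfanyl chain, is recorded as "not active" (no number reported) in the same assay. Nothing measured here on the groups themselves accounts for the size of this step.

One swap changes several things at once, the sulfur link, the ring type and the two methoxy groups, so the compounds shown cannot say which of these carries the loss. A plain phenyl group, a cyclohexyl group joined directly to the aromatic carbon, or a phenyl ring with a single methoxy group would help to separate these changes, and an amine-bearing ring would test how the position responds to a quite different kind of group.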